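The source may hold more compounds than are shown below. What is called first, only, known or untested is meant among the compounds shown, and "the series" means these compounds.

Compound 2 `COc1cc(-c2c(C)nn(C)c2C)ccc1-c1nnc(N(C)Cc2ccc3nccn3c2)o1` stands at 2000 nM in an assay on COS-7 cells for inhibition of tyrosine-protein kinase receptor UFO (Homo sapiens), read by ELISA, with a stated time of 1 h (a lower number here means a stronger inhibitor, a higher number a weaker inhibitor), and compound 1 `Cc1nn(C)c(C)c1-c1ccc(-c2nnc(N(C)Cc3ccc4nccn4c3)o2)cc1` stands at 3160 nM, the two lying within the scatter of each other. The step of a 1.6-fold lower number from compound 1 to compound 2 (0.20 log units; within the scatter), a methoxy in place of hydrogen on an aromatic carbon, is thus small. Compound 3 `Cc1nn(C)c(C)c1-c1ccc(-c2nnc(N(C)Cc3ccc4nccn4c3)o2)c(C#N)c1` takes the next step at the same position: cyano in place of methoxy on an aromatic carbon, on an aromatic carbon of a six-membered aromatic ring of carbon only, ortho to a large group and meta to the 1,3,5-trimethyl-1H-pyrazol-4-yl group. Going by the values given here, only the step from compound 1 to compound 2 bears on this position, and it shows merely that a methoxy there changes little against hydrogen; nothing measured tells how a cyano behaves there. Among the compounds with values here, the expectation for compound 3 is therefore a step of no size beyond the scatter, a 1.3-fold higher number from compound 2 to compound 3 (0.10 log units; within the scatter), with a wide margin in either direction because the only guidance is a 1.6-fold lower number from compound 1 to compound 2 (0.20 log units; within the scatter). Compound 3 is estimated at 2500 nM in this assay, within a range from 800 nM to 8000 nM.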

Compound 3, half-maximal inhibitory concentration: > 31600 nM
Compound 3: a limit, no number (the forecaster's own chance of this, stated with the estimate: 5%); middle value at least 12-fold (1.10 log units) away from the limit.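

The position on the six-membered aromatic ring of carbon only, ortho to a large group and meta to a 1,3,5-trimethyl-1H-pyrazol-4-yl group, had looked undemanding, but it does not accept every small group alike: cyano in place of methoxy gives an at least 15-fold higher number from compound 2 to compound 3 (1.19 log units; beyond the scatter), and cyano in place of hydrogen gives an at least 10-fold higher number from compound 1 to compound 3 (1.00 log units; beyond the scatter), so both steps lie beyond the scatter. Methoxy and cyano have the same counts of heavy atoms and hydrogen-bond acceptors, and neither carries a net charge, so these counts do not separate the two groups, while the triple bond is the counted feature found only in cyano. In this assay compound 3 stands at a limit of the assay and not at a number, which leaves each step a minimum: the limit of > 31600 nM in this assay, at which 1 of the 3 values shown sits.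

From the compounds shown here alone, how far past that limit compound 3 lies remains open, as does whether the triple bond itself matters. The compounds shown also leave open how an amine, a carboxylic acid or a longer chain such as ethoxy would behave at this position.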